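The compounds below may be only part of what the source reports. "The series", "measured", "known", "first", "only" and "open" are said of these compounds alone.

Measured compounds:
compound 1, `CCCCCCCCCCc1ccc(-c2noc(CCCN)n2)cc1`: 67%
compound 2, `CCCCCCCCCCc1ccc(-c2noc(CCCCN)n2)cc1`: 55%

In an assay on HeLa cells for inhibition of sphingosine-1-phosphate transporter SPNS2 (Mus musculus), read by LC-MS, tested at 2 uM (on this read-out lower numbers stand for less inhibition and higher numbers for more inhibition at the one concentration tested (going by the name of the read-out)), compound 1 stands highest of the two numbers. For the measured compounds named here, the only other measured compound, compound 2, gives 55%, and the step of a number 12 percentage points lower from compound 1 to compound 2 (beyond the scatter) goes with a small change at the amine end of the chain on the core.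

The new compound is compound 3, `CCCCCCc1ccc(-c2noc(CCCN)n2)cc1`. It differs from compound 1 on the other side of the core: hydrogen in place of butyl on a saturated chain carbon, six bonds along the chain from an aromatic carbon. Going by the values given here, no measured step touches this long chain, so the one known step, a number 12 percentage points lower from compound 1 to compound 2 (beyond the scatter), gives no direct guide; it only shows that even a small change at one end of the molecule moves the number beyond the scatter. On that basis a larger change is expected here, downward. Compound 3 is estimated at 30%, with a likely range from 5% to 60%, meaning an expected step of a number 37 percentage points lower from compound 1 to compound 3 (beyond the scatter).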

Compound 3, a percentage reported as inhibition, at one concentration (the size of the read-out at that concentration, not a potency): 55%
The estimate for compound 3 lay 25 percentage points below the measured number; measured number inside the range.
By their numbers in this assay, from the lowest: compounds 2 and 3 (each within the scatter of the next); then compound 1.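

In this assay the long chain on the core had not been varied until now, and the step of a number 12 percentage points lower from compound 1 to compound 3 (beyond the scatter) comes with hydrogen in place of butyl on a saturated chain carbon, six bonds along the chain from an aromatic carbon. This shows that the outer part of the chain matters to the read-out, so both ends of the molecule can now be said to affect it. Removing butyl lowers the number only modestly, however, and inhibition at the one concentration tested does not disappear.

The compounds shown leave open how a longer chain, or a chain ending in a phenyl ring, would read, and whether a carboxylic acid could stand in place of the amine. No measurement here explains why the shorter chain reads as it does.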